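This account rests on a few compounds, and the source may have more. Where it says the series, first, only, none or still open, it means among the compounds named here.

Measured compounds:
compound 1 `CCN(C)/N=N/c1ccc(NC(N)=O)cc1`: 3.87
compound 2 `CN(C)/N=N/c1c(F)cccc1F`: 3.63

In a functional assay on L1210 cells (Mus musculus) for antiproliferative activity (on this read-out lower numbers stand for lower potency and higher numbers for higher potency (the scale is a negative logarithm)), compound 1 gives 3.87. In this assay compound 2 gives 3.63. The two values lie within the usual scatter of one another, so neither compound can be set apart from the other on this read-out; compound 1 simply holds the higher of the two numbers recorded, and nothing beyond that can be read from the pair.

Compound 3 `C=CCN(C)/N=N/c1ccc(NC(N)=O)cc1` has not yet been measured. It differs from compound 1 by vinyl in place of methyl on a saturated chain carbon bound to an amine nitrogen. Within the data shown here, no step between two measured compounds that differ in only one place is available, and compound 1 and compound 2 differ in several places at once, so their two values offer no guide to this particular change. The change itself is a small one at the chain on the amine nitrogen, with no ring, no donor and no acceptor entering or leaving.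

The step from compound 1 to compound 3 is therefore expected to be small, with no clear direction, and most likely none beyond the scatter. Compound 3 is expected to give about 3.95 in this assay, with a range from 3.5 to 4.4. This estimate corresponds to a step of a number 0.08 log units higher from compound 1 to compound 3 (within the scatter), expected to fall within the scatter.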

Compound 3, logarithm of the reciprocal of the active concentration, log(1/C): 3.77
Compound 3: middle estimate off by 0.18 log units, on the high side; the range from low to high includes it.
By their numbers in this assay, from the lowest: compounds 2, 3 and 1 (each within the scatter of the next).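

With the urea-bearing core of compound 1 held constant, the series now has its first step that differs in one place: ethyl(methyl)amino to allyl(methyl)amino, with vinyl in place of methyl on a saturated chain carbon bound to an amine nitrogen, gives a number 0.10 log units lower from compound 1 to compound 3 (within the scatter) in this assay. At this position, therefore, the added carbon and the double bond outside aromatic rings leave the two compounds indistinguishable on this read-out, a comparison that the pair of compounds 1 and 2, differing in several places, could not provide. No measurement shown offers an explanation for this result.

The compounds shown leave open whether a larger departure at this chain, such as a hexyl chain, a terminal hydroxyl or a carboxylic acid in place of the allyl group, would produce a step beyond the scatter. They also leave open whether the exchange of ethyl for allyl gives a similar result when the urea group on the core is replaced by an amine.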